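The source may hold more compounds than are shown below. What is called first, only, known or untested is meant among the compounds shown, and "the series" means these compounds.

Measured compounds:
- compound 1 `O=C(c1ccc(C#Cc2ccc(Oc3ccccc3)cc2)cc1)N1CCC[C@@H](CO)C1`; in a functional assay on TREX cells for negative allosteric modulation of metabotropic glutamate receptor 3 (Rattus norvegicus), read by calcium flux, with a stated time of 2.5 min (on this read-out lower numbers stand for stronger inhibition and higher numbers for weaker inhibition), compound 1 gives > 10000 nM, a limit of the assay.
- compound 2 `O=C(c1ccc(C#Cc2ccc(O)cc2)cc1)N1CCC[C@@H](CO)C1`; in this assay compound 2 gives > 10000 nM, likewise a limit.

Compound 2 stands at the assay limit, and so does the other measured compound; nothing among the numbers shown places it relative to anything else. Going by the values given here, the one measured step, a step that the two limits leave unreadable from compound 1 to compound 2, cannot be read because both ends sit at the limit (the limit of > 10000 nM in this assay, at which 2 of the 2 values shown sit).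

Compound 3 `O=C(c1ccc(C#Cc2ccc(OC(F)(F)F)cc2)cc1)N1CCC[C@@H](CO)C1` differs from compound 2 by trifluoromethyl in place of hydrogen on an oxygen on an aromatic ring. Among the compounds with values here, no measured step bears on this change in a readable way, since the only step available runs between two limits. The expectation for compound 3 therefore rests on the two limits alone: the most probable outcome is that it again reports a limit in this assay, with the estimated step of an at least 1.1-fold lower number from compound 2 to compound 3 (0.04 log units; that floor lies within the scatter) being no step beyond the scatter. Compound 3 is estimated at 9000 nM, with a range from 2000 nM to 40000 nM.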

Compound 3, half-maximal inhibitory concentration: > 10000 nM
Compound 3: only a limit was reported; the forecaster's own chance of this, stated with the estimate: 65%; middle value at least 1.1-fold (0.04 log units) from the limit.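

In this assay compound 3 gives > 10000 nM, a limit of the assay. No step among compound 1, compound 2 and compound 3 can be read, because all three stand at that limit: the limit of > 10000 nM in this assay, at which 3 of the 3 values shown sit.

The compounds shown leave open how these three rank and whether any group on this oxygen gives a numerical inhibition value.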